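Aryl swap on the amide nitrogen of compound 1

This account rests on a few compounds, and the source may have more. Where it says the series, first, only, none or still open, it means among the compounds named here.

Measured compounds:
compound 1 `CCc1cccc(NC(=O)CN2CCC(c3cccc[n+]3[O-])CC2)c1`: 95 nM
compound 2 `Cc1cc(C(=O)NCN2CCC(c3cccc[n+]3[O-])CC2)ccc1F`: 50 nM
compound 3 `Cc1cccc(C(=O)NCN2CCC(c3ccccn3)CC2)c1`: 9 nM

In a functional assay on HEK293 cells for agonist activity at D(4) dopamine receptor (Homo sapiens), read by FLIPR (on this read-out higher numbers stand for an effect only at larger amounts of compound and lower numbers for an effect already at smaller amounts), compound 1 gives 95 nM, the highest of the three numbers. The nearest is compound 2 with 50 nM, a gap that lies within the scatter, so no order between the two can be claimed. The furthest is compound 3 with 9 nM, a gap beyond the scatter; compound 3 also differs from compound 1 in more than one place, so the gap cannot be assigned to any single change.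

Compound 4 `Cc1cc(Br)ccc1NC(=O)CN1CCC(c2cccc[n+]2[O-])CC1` is not yet measured. It differs from compound 1 in one place: 4-bromo-2-methylphenyl in place of 3-ethylphenyl on an amide-type nitrogen. Among the measured compounds shown here, no pair among the measured compounds differs in a single place, so there is no measured step to lean on for this exchange. Since both groups are aromatic rings of the same heavy-atom count, with no change in donors, acceptors or charge, the expectation is a step of no more than the usual scatter. The step expected here, a 1.1-fold lower number from compound 1 to compound 4 (0.02 log units; within the scatter), is therefore small. Compound 4 is estimated at 90 nM, with a range from 35 nM to 230 nM.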

Compound 4, half-maximal effective concentration: 66 nM
Estimate against measurement, compound 4: 1.4-fold (0.13 log units) above, within the range that was stated.
By their numbers in this assay, from the lowest: compound 3; then compounds 2, 4 and 1 (each within the scatter of the next).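

In this assay, among the compounds shown here, 4-bromo-2-methylphenyl in place of 3-ethylphenyl on the amide-type nitrogen gives a 1.4-fold lower number from compound 1 to compound 4 (0.16 log units; within the scatter), the first single-place step, and it lies within the scatter. For this pair, then, one aromatic ring of carbon only can replace another of the same heavy-atom count, with a different set of substituents, without a readable shift in the number. No data on the properties of either group accompany this step, so nothing can be said about a cause.

Open, from the compounds shown here alone, is whether the bromine or the methyl alone would give the same reading, as 4-bromophenyl or 2-methylphenyl on this nitrogen would show. Also open, going by these compounds, is whether this nitrogen tolerates a non-aromatic group such as cyclohexyl, or a ring carrying a carboxylic acid or an amine.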